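From fluoro to methoxy in a level cytotoxicity series

A few compounds are considered here, and "the series" means these few. Any claim that something is new, unique, unknown or untested is made for them only; others in the source may bear on it.

Of the compounds shown here, three sharing one core have been measured in an ADME assay on HUVEC cells (Homo sapiens) for cytotoxicity, read by MTT assay, with a stated time of 24 h (on this read-out lower numbers stand for higher toxicity in this test and higher numbers for lower toxicity in this test), and their numbers lie close together. Compound 1 `Brc1cccc(/C=C/c2nnc(-c3ccc4c(c3)OCCO4)o2)c1` gives 322000 nM and compound 2 `O=[N+]([O-])c1ccccc1/C=C/c1nnc(-c2ccc3c(c2)OCCO3)o1` gives 323000 nM while compound 3 `Fc1ccc(/C=C/c2nnc(-c3ccc4c(c3)OCCO4)o2)cc1` gives 325000 nM and so stands level with both, within the scatter of each. Compound 4 `COc1ccc(/C=C/c2nnc(-c3ccc4c(c3)OCCO4)o2)cc1` has not yet been measured. It carries methoxy in place of fluoro on an aromatic carbon, para to a large group (methoxy in place of fluoro on an aromatic carbon). Going by the values given here, one measured step touches the same group, 4-fluorophenyl in place of 3-bromophenyl (a 1.0-fold higher number from compound 1 to compound 3 (0.00 log units; within the scatter)), and it lies within the scatter. Among the compounds with values here, no measured compound carries methoxy, so this exchange itself is untested, but no step beyond the scatter has appeared so far. The step expected in this assay is therefore none beyond the scatter (a 1.0-fold lower number from compound 3 to compound 4 (0.01 log units; within the scatter)). Compound 4 is estimated at 320000 nM with an expected range from 220000 nM to 440000 nM in this estimate.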

Compound 4, half-maximal cytotoxic concentration: 312000 nM
For compound 4 the middle estimate is 1.0-fold (0.01 log units) above the measured one, within the range that was stated.
By their numbers in this assay, from the lowest: compounds 4, 1, 2 and 3 (each within the scatter of the next).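

In this assay, the exchange of fluoro for methoxy on this aromatic carbon, para to a large group, now has a direct reading: a 1.0-fold lower number from compound 3 to compound 4 (0.02 log units; within the scatter). Methoxy brings a hydrogen-bond acceptor that fluoro does not, and the 4-methoxyphenyl group also stands level with the 3-bromophenyl group (a 1.0-fold lower number from compound 1 to compound 4 (0.01 log units; within the scatter)), so no exchange among the four compounds shown has yet produced a step beyond the scatter. Nothing available here accounts for these level numbers.

From the compounds shown here alone, whether an amine or a carboxylic acid on this carbon, or a longer chain in place of methoxy, would give a step beyond the scatter remains open. Going by these compounds, all four compounds keep the shared core, so it is also open whether the numbers stay level when that core is changed.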